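This account rests on a few compounds, and the source may have more. Where it says the series, first, only, none or still open, it means among the compounds named here.

Measured so far in a functional assay on ZR-75-1 cells (Homo sapiens) for inhibition, read by sulforhodamine B assay; a lower number here means a stronger inhibitor of growth, a higher number a weaker inhibitor of growth:
- compound 1 `Cc1ccc2[nH]c(-c3ccc(-c4ccc(-c5cccc(Cl)c5)cc4)cc3)nc2c1` gives 3450 nM
- compound 2 `FC(F)(F)c1ccc(-c2ccc(-c3ccc(-c4nc5ccccc5[nH]4)cc3)cc2)cc1` gives 48300 nM
- compound 3 `Clc1cccc(-c2ccc(-c3ccc(-c4nc5ccccc5[nH]4)cc3)cc2)c1` gives 41200 nM

Of these three, compound 1 has the lowest number, and so is the strongest inhibitor of growth. Compound 4 `Cc1ccc2[nH]c(-c3ccc(-c4ccc(-c5ccc(OC(F)(F)F)cc5)cc4)cc3)nc2c1` keeps the core of compound 1 with its methyl, and only the end group changes: 4-(trifluoromethoxy)phenyl in place of 3-chlorophenyl on an aromatic carbon.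

Going by the values given here, two measured steps bear on this change. Losing the methyl gave a 12-fold higher number from compound 1 to compound 3 (1.08 log units; beyond the scatter), a large step, but compound 4 keeps that methyl, so this step should not come into play. The closest guide is an exchange of end groups on the core without the methyl, which gave a 1.2-fold lower number from compound 2 to compound 3 (0.07 log units; within the scatter). That exchange involves a different pair of groups, and the 4-(trifluoromethoxy)phenyl group itself has not been measured, so the guide is only a loose one.

In this assay no step beyond the scatter is therefore expected. The expected step is a 1.2-fold higher number from compound 1 to compound 4 (0.06 log units; within the scatter). Compound 4 is estimated at 4000 nM, with an expected range from 1500 nM to 12000 nM.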

Compound 4, concentration for 50% growth inhibition: 2410 nM
Beside the measured number, compound 4's estimate is 1.7-fold (0.22 log units) above it; low and high end bracket the measured number.
By their numbers in this assay, from the lowest: compounds 4 and 1 (each within the scatter of the next); then compounds 3 and 2 (each within the scatter of the next).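

In this assay, the first end-group exchange seen on the methyl-bearing core gives a 1.4-fold lower number from compound 1 to compound 4 (0.16 log units; within the scatter). The earlier exchange, between compound 2 and compound 3, was on the core without the methyl, so this result shows that on the methyl-bearing core, too, a change of end group need not move the number beyond the scatter, even with 4-(trifluoromethoxy)phenyl, at 11 heavy atoms, replacing 3-chlorophenyl, at 7. No measurement shown here explains why these two end groups give such similar numbers.

From the compounds shown here alone, it remains open whether an end ring carrying an amine or a carboxylic acid would give a similar number on this core. Also open, going by these compounds, is whether removing the methyl would matter as much with 4-(trifluoromethoxy)phenyl as with 3-chlorophenyl.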